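The source may hold more compounds than are shown below. What is called first, only, known or untested is meant among the compounds shown, and "the series" means these compounds.

Measured so far:
- compound 1, `N#Cc1cc(NCc2ccccc2[N+](=O)[O-])c2cn[nH]c2c1`: 22%
- compound 2, `CC(C)n1ncc2c(NCc3ccccc3[N+](=O)[O-])cc(C(F)(F)F)cc21`: 35%

Both numbers come from an assay for inhibition of Tryptophan 2,3-dioxygenase (Homo sapiens), with stated times of 10 min and 60 min, tested at 10 uM; a lower number here means a weaker effect, a higher number a stronger effect of the compound at the concentration tested. Compound 2 gives the higher of the two, and its gap to compound 1 lies beyond the usual scatter of this assay.

Compound 3, `O=[N+]([O-])c1ccccc1CNc1cc(C(F)(F)F)cc2[nH]ncc12`, has not yet been measured in this assay. It differs from compound 2 in one place: hydrogen in place of isopropyl on an aromatic nitrogen. Within the data shown here, no step between two measured compounds shows this change alone, so its effect is open. With compound 1, which also carries a hydrogen there, giving 22%, a small downward step a number 9 percentage points lower from compound 2 to compound 3 (within the scatter) is expected, possibly within the scatter. Compound 3 is estimated at 26%, between 10% and 45%.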

Compound 3, a percentage reported as inhibition, at one concentration (the size of the read-out at that concentration, not a potency): 89%
Compound 3: middle estimate off by 63 percentage points, on the low side; measured number above the stated range.
By their numbers in this assay, from the lowest: compound 1; then compound 2; then compound 3.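

Hydrogen in place of isopropyl on the aromatic nitrogen gives a number 54 percentage points higher from compound 2 to compound 3 (beyond the scatter) and so the isopropyl on this nitrogen is far from neutral in this series. With hydrogen on that nitrogen, trifluoromethyl in place of cyano on an aromatic carbon gives a number 67 percentage points higher from compound 1 to compound 3 (beyond the scatter) and shows that this second place also strongly changes the read-out. Nothing available explains either step.

As far as these compounds go, whether a methyl or an ethyl on that nitrogen would stay close to compound 3 or fall towards compound 2 remains open. So does the effect of a chlorine or a carboxylic acid in place of the trifluoromethyl.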